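The source may hold more compounds than are shown below. What is called first, only, known or untested is meant among the compounds shown, and "the series" means these compounds.

Working notes on the sulfonyl-styryl series, read in a functional assay on DU-145 cells (Homo sapiens) for cytotoxicity, read by trypan blue exclusion, with a stated time of 96 h; a lower number here means a stronger inhibitor, a higher number a weaker inhibitor.

Two compounds carry numbers. Compound 1 `COc1ccc(CS(=O)(=O)/C=C/c2c(OC)cccc2OC)cc1[N+](=O)[O-]` gives 20000 nM. Compound 2 `COC(=O)C(F)(F)Nc1cc(CS(=O)(=O)/C=C/c2c(OC)cc(OC)cc2OC)ccc1OC` gives 250 nM, the lowest of the two numbers shown; its nearest neighbour is compound 1, whose number stands far higher, well beyond the scatter. The two do not differ in a single place, so no step between measured compounds can be drawn from them, and no cause for the gap is offered.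

Compound 3 `COc1cc(OC)c(/C=C/S(=O)(=O)Cc2ccc(OC)c(NC(C(=O)O)c3ccc(F)cc3)c2)c(OC)c1` is the next compound to be measured. It keeps the core of compound 2 and differs from it only at one point: carboxy(4-fluorophenyl)methyl in place of difluoro(methoxycarbonyl)methyl on a nitrogen on an aromatic ring. For the measured compounds named here, nothing measured here tells how a change at that nitrogen moves the number, since no pair of measured compounds isolates it. The expectation for compound 3 is therefore anchored on compound 2, whose 250 nM is the only reference, and the step is expected to be small, a 1.6-fold higher number from compound 2 to compound 3 (0.20 log units; within the scatter), possibly none beyond the scatter. Compound 3 is estimated at 400 nM, within 100 nM to 2000 nM.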

Compound 3, half-maximal inhibitory concentration: 150 nM
Compound 3: middle estimate off by 2.7-fold (0.43 log units), on the high side; the range from low to high includes it.
By their numbers in this assay, from the lowest: compounds 3 and 2 (each within the scatter of the next); then compound 1.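

At the nitrogen on an aromatic ring, this assay now gives its first step that isolates a single change: a 1.7-fold lower number from compound 2 to compound 3 (0.22 log units; within the scatter), with carboxy(4-fluorophenyl)methyl in place of difluoro(methoxycarbonyl)methyl. This pair shows that a substituent with no ring and 7 heavy atoms can give way to one with a six-membered aromatic ring of carbon only and 11 heavy atoms, with a hydrogen-bond donor entering as well, and the two compounds stay inseparable in this read-out. Nothing measured in the series accounts for how close the two compounds lie, and the change at this nitrogen remains a description of one pair and not a trend.

The carboxylic acid, the aromatic ring and the fluorine all enter in one step, and the two fluorines and the methyl ester leave in that same step, so the pair cannot assign the outcome to any one of these parts. Also open, as far as these compounds go, is how the number would respond to a simpler group on this nitrogen, such as a plain amine, an acetyl amide or an unsubstituted phenyl in place of the 4-fluorophenyl.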